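The compounds below may be only part of what the source reports. "The series", "measured", "known", "first", "only" and "open" are said of these compounds alone.

Cytotoxicity across the series is weak. In an ADME assay on CHO cells (Cricetulus griseus) for cytotoxicity, read by MTT assay (on this read-out higher numbers stand for weaker inhibition and lower numbers for stronger inhibition), compound 1 `Cc1cc(N)n(-c2nc(C(F)(F)F)cc(=O)[nH]2)n1` gives 120000 nM. Compound 2 `CCOc1cc(C)nn1-c1nc(C(F)(F)F)cc(=O)[nH]1` reaches only a limit of the assay, > 50000 nM, in this assay. The step that the limit leaves unreadable from compound 1 to compound 2 therefore cannot be sized; it falls on (the limit of > 50000 nM in this assay, at which 1 of the 3 values shown sits). Compound 3 `Cc1cc(NCCN(C)C)n(-c2nc(C(F)(F)F)cc(=O)[nH]2)n1` has no number at all in this assay; its entry reads "not determined" (no result reported), so there is no measured starting point for the step to compound 4 `Cc1cc(NC2CCOCC2)n(-c2nc(C(F)(F)F)cc(=O)[nH]2)n1`.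

The change is oxan-4-yl in place of 2-(dimethylamino)ethyl on a nitrogen on an aromatic ring. Within the data shown here, no measured step in this assay involves either of these two groups; the only step in hand, the ethoxy for amino change from compound 1 to compound 2, touches a different position and is itself unreadable. No direction can be expected from the data beyond the scatter.

Given that compound 1 gives 120000 nM in this assay, compound 4 is expected to remain a weak inhibitor in this assay, estimated at 100000 nM, within 40000 nM to 250000 nM.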

Compound 4, half-maximal inhibitory concentration: 18000 nM
Compound 4: middle estimate off by 5.6-fold (0.74 log units), on the high side, outside the stated range (below it).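

In this assay, the amino nitrogen turns out to be a position where substitution registers: oxan-4-yl in place of hydrogen gives a 6.7-fold lower number from compound 1 to compound 4 (0.82 log units; beyond the scatter). Putting (oxan-4-yl)amino in place of ethoxy on the aromatic carbon gives an at least 2.7-fold lower number from compound 2 to compound 4 (0.44 log units; beyond the scatter). That second step is only a bound, since compound 2 stands at a limit of the assay: the limit of > 50000 nM in this assay, at which 1 of the 4 values shown sits.

Steps from compound 3 cannot be read, which leaves 2-(dimethylamino)ethyl without any comparison to oxan-4-yl on this nitrogen. Also open, going by these compounds, is whether the lower number depends on the ring oxygen, on the ring itself or on any substituent at all, a question that a cyclohexyl group or a plain ethyl chain on the same nitrogen would help to separate.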